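The compounds below may be only part of what the source reports. "The series", "measured", "known", "first", "only" and "open" are said of these compounds alone.

Working notes on the series. Compound 1 `COc1cc(Cn2cc(CNC(=O)c3cn(-c4ccccc4)nc3-c3ccccc3)nn2)cc(OC)c1` gives 2400 nM in a functional assay on MCF7 cells (Homo sapiens) for antiproliferative activity, read by sulforhodamine B assay, with a stated time of 48 h; on this read-out lower numbers stand for stronger inhibition of growth and higher numbers for weaker inhibition of growth. Compound 2 `COc1cc(Cn2cc(CNC(=O)c3cn(-c4ccccc4)nc3-c3ccccc3)nn2)cc(OC)c1OC` gives > 100000 nM in this assay, a limit of this assay and not a number, sitting at the limit of > 100000 nM in this assay, at which 1 of the 3 values shown sits. The change methoxy in place of hydrogen on an aromatic carbon therefore produces an at least 41-fold higher number from compound 1 to compound 2 (1.61 log units; beyond the scatter). Compound 3 `COc1ccc(Cn2cc(CNC(=O)c3cn(-c4ccccc4)nc3-c3ccc(F)cc3)nn2)cc1` gives 650 nM in this assay, the lower number of the two measured compounds; the difference between the core of compound 3 and the core of compound 1 is not broken down here. Compound 4 `COc1ccc(Cn2cc(CNC(=O)c3cn(-c4ccccc4)nc3-c3ccc(F)cc3)nn2)cc1OC` is not yet measured; it carries the change (methoxy in place of hydrogen on an aromatic carbon), the same kind of change as before, but here the entering group sits ortho to one methoxy group and meta to a large group, where before it sat ortho to two methoxy groups and para to a large group. For this assay an estimated step of a 9.2-fold higher number from compound 3 to compound 4 (0.97 log units; beyond the scatter) is expected from compound 3 to compound 4, smaller than an at least 41-fold higher number from compound 1 to compound 2 (1.61 log units; beyond the scatter) since the surroundings of the place differ. Compound 4 is thus estimated at 6000 nM, between 1500 nM and 60000 nM.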

Compound 4, concentration for 50% growth inhibition: > 100000 nM
Compound 4 was reported as a limit (the forecaster's own chance of this, stated with the estimate: 20%); middle value at least 16-fold (1.22 log units) from the limit.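

In this assay compound 4 gives > 100000 nM, a limit of the assay and not a number. Methoxy in place of hydrogen on an aromatic carbon gives an at least 150-fold higher number from compound 3 to compound 4 (2.18 log units; beyond the scatter), so the change raises the number in the same direction on both cores, although the entering group sits in different surroundings: the same change on two cores in this assay, an at least 41-fold higher number (1.61 log units; beyond the scatter) from compound 1 to compound 2 and an at least 150-fold higher number (2.18 log units; beyond the scatter) from compound 3 to compound 4; the limit leaves it open whether they differ Neither step has a true end point, so the data show the direction carrying over from one core to the other, but not whether its size carries over.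

The compounds shown leave open whether the rise belongs to methoxy itself or to any group at that place. A fluorine, a hydroxyl or an amine on the same aromatic carbon would help to separate these.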